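The source may report more compounds than this note shows. Statements on the series, on what has been measured and on what is new or still open speak of the compounds shown alone.

Compound 3 `Cc1ccc(OCC(=O)N(O)Cc2cccs2)cc1` stands highest of the three measured numbers in an assay on HEK293 cells for agonist activity at transient receptor potential cation channel subfamily M member 8 (Homo sapiens), read by fluorescence and calcium flux, with a stated time of 15 min (on this read-out higher numbers stand for an effect only at larger amounts of compound and lower numbers for an effect already at smaller amounts), giving 8000 nM. Compound 1 `Cc1ccc(OCC(=O)N(Cc2cccs2)CC(C)C)cc1` gives 900 nM in this assay, and compound 2 `CCCN(Cc1cccs1)C(=O)COc1ccc(C)cc1` gives 40 nM. Compound 4 `Cc1ccc(OCC(=O)N(Cc2cccs2)c2cnn(C)c2)cc1` differs from compound 3 by 1-methyl-1H-pyrazol-4-yl in place of hydroxy on an amide-type nitrogen. The measured steps that bear on this change run the other way: a 200-fold higher number from compound 2 to compound 3 (2.30 log units; beyond the scatter) and an 8.9-fold higher number from compound 1 to compound 3 (0.95 log units; beyond the scatter). Both show a carbon substituent on that nitrogen giving a lower number than hydroxy, though no aryl group there has yet been measured, and a 23-fold lower number from compound 1 to compound 2 (1.35 log units; beyond the scatter) shows that the shape of the substituent matters greatly. A lower number is therefore expected, by a 16-fold lower number from compound 3 to compound 4 (1.20 log units; beyond the scatter). Compound 4 is estimated at 500 nM, in a range from 80 nM to 3000 nM.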

Compound 4, half-maximal effective concentration: 63000 nM
Compound 4: middle estimate off by 130-fold (2.10 log units), on the low side, and the stated range ends below it.
By their numbers in this assay, from the lowest: compound 2; then compound 1; then compound 3; then compound 4.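

In this assay, 1-methyl-1H-pyrazol-4-yl on the amide-type nitrogen brings a 7.9-fold higher number from compound 3 to compound 4 (0.90 log units; beyond the scatter) and shows that a carbon substituent there need not give a lower number than hydroxy, as the chains of compound 1 and compound 2 did. Against those chains, the same group brings a 70-fold higher number from compound 1 to compound 4 (1.85 log units; beyond the scatter) and a 1600-fold higher number from compound 2 to compound 4 (3.20 log units; beyond the scatter) and gives the highest number of the four. Nothing given here explains this order. Open, from the compounds shown here alone, is where a phenyl ring, a cyclopropyl ring or a butyl chain on that nitrogen would fall.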